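A few compounds are considered here, and "the series" means these few. Any claim that something is new, unique, unknown or untested is made for them only; others in the source may bear on it.

Measured in a functional assay on NCI-H1975 cells (Homo sapiens) for antiproliferative activity, read by CCK-8 assay, with a stated time of 72 h; on this read-out lower numbers stand for stronger inhibition of growth and higher numbers for weaker inhibition of growth:
- Compound 1 `CC[C@@H]1C(=O)N(C)c2cnc(-n3ccc4cc(C(N)=O)ccc43)nc2N1C1CCCC1`: 3380 nM
- Compound 2 `CCC1C(=O)N(C)c2cnc(-n3ccc4cc(C(=O)NC(C)C)ccc43)nc2N1c1ccn(C)n1`: 12200 nM
- Compound 3 `CC[C@@H]1C(=O)N(C)c2cnc(Nc3ccc(S(=O)(=O)NCCCO)cc3)nc2N1C1CCCC1`: 2140 nM

Among these three, compound 2 has the highest number, which means the weakest inhibition of growth. Its gaps to compound 1 and to compound 3 both lie beyond the usual scatter of repeated measurements.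

The next compound to consider is compound 4 `CCC1C(=O)N(C)c2cnc(-n3ccc4cc(F)ccc43)nc2N1c1ccn(C)n1`, which has not yet been measured in this assay. It differs from compound 2 in one place: fluoro in place of isopropylcarbamoyl on an aromatic carbon. The group that enters is much smaller than the group that leaves.

For the measured compounds named here, no measured pair of compounds shows this change on its own, so the data give no direct guide to its effect. The three measured compounds differ from one another in several places at once. With only compound 2 at 12200 nM as a starting point, the working expectation is that growth inhibition stays weak, with no shift beyond the scatter in either direction.

The estimated step is a 1.2-fold lower number from compound 2 to compound 4 (0.09 log units; within the scatter). For compound 4 the expected value is 10000 nM, with an estimated range from 3000 nM to 30000 nM.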

Compound 4, concentration for 50% growth inhibition: 28600 nM
Beside the measured number, compound 4's estimate is 2.9-fold (0.46 log units) below it, within the range that was stated.
By their numbers in this assay, from the lowest: compounds 3 and 1 (each within the scatter of the next); then compound 2; then compound 4.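

In this assay, for the compounds shown here, the exchange of isopropylcarbamoyl for fluoro on this aromatic carbon gives a 2.3-fold higher number from compound 2 to compound 4 (0.37 log units; beyond the scatter) and so provides the first direct reading for this position. The step is modest but lies beyond the scatter, which means the group on this carbon of the six-membered aromatic ring of carbon only does matter to growth inhibition, at least with the rest of compound 2 held fixed. Here the larger group, which carries a hydrogen-bond donor and a hydrogen-bond acceptor, goes with the stronger inhibition, although a single pair cannot show whether size, those hydrogen-bonding features or something else accounts for the difference. No accompanying measurement bears on why the number rises.

The compounds shown leave open how a plain hydrogen, an amine or a carboxylic acid on this carbon would compare with isopropylcarbamoyl and fluoro, and such groups could begin to separate those possibilities. They also leave open whether the same step would appear with a different group in place of the other parts of compound 2, since this change has been read only once.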